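Replacing a urea by an amide on the shared core

A few compounds are considered here, and "the series" means these few. Any claim that something is new, unique, unknown or untested is made for them only; others in the source may bear on it.

Compound 1 `NC(=O)c1ccc2c(ccn2-c2ccc(NC(=O)c3cccc(C(F)(F)F)c3)cc2)n1`: > 10000 nM in a functional assay on A375P cells (Homo sapiens) for cytotoxicity, read by MTT assay (a lower number here means a stronger inhibitor, a higher number a weaker inhibitor), a limit rather than a number. Compound 2 `COC(=O)c1ccc2c(ccn2-c2ccc(NC(=O)Nc3cccc(Cl)c3Cl)cc2)n1`: 6400 nM. Compound 3 `COC(=O)c1ccc2c(ccn2-c2ccc(NC(=O)Nc3ccc(Cl)c(Cl)c3)cc2)n1`: 3800 nM.

Compound 3 gives the lowest of the two numbers, though the move a 1.7-fold lower number from compound 2 to compound 3 (0.23 log units; within the scatter) stays within the scatter, so the two cannot be ranked. Compound 4 `COC(=O)c1ccc2c(ccn2-c2ccc(NC(=O)c3cccc(C(F)(F)F)c3)cc2)n1` is made from compound 3 by 3-(trifluoromethyl)phenyl in place of (3,4-dichlorophenyl)amino on a carbonyl carbon. Among the measured compounds shown here, no measured step covers this exchange. Compound 1 carries the same 3-(trifluoromethyl)phenyl on a carbonyl carbon and reaches only the limit (the limit of > 10000 nM in this assay, at which 1 of the 3 values shown sits), differing from compound 4 elsewhere in the shared core. A weakening step a 2.1-fold higher number from compound 3 to compound 4 (0.32 log units; beyond the scatter) is therefore expected, with a fair chance of a limit again. Compound 4 is estimated at 8000 nM (range 3000 nM to 25000 nM).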

Compound 4, half-maximal inhibitory concentration: 9500 nM
Estimate against measurement, compound 4: 1.2-fold (0.07 log units) below, within the range that was stated.
By their numbers in this assay, from the lowest: compounds 3, 2 and 4 (each within the scatter of the next, the first and the last beyond it). At a limit, above all of these: compound 1.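

In this assay, 3-(trifluoromethyl)phenyl in place of (3,4-dichlorophenyl)amino on a carbonyl carbon gives a 2.5-fold higher number from compound 3 to compound 4 (0.40 log units; beyond the scatter), so replacing this urea by an amide weakens the compound modestly. Against the other urea, the exchange gives a 1.5-fold higher number from compound 2 to compound 4 (0.17 log units; within the scatter), which separates nothing. Methoxy in place of amino on a carbonyl carbon gives an at least 1.0-fold lower number from compound 1 to compound 4 (0.02 log units; that floor lies within the scatter), which cannot be read as a real change, as compound 1 stands at a limit: the limit of > 10000 nM in this assay, at which 1 of the 4 values shown sits.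

Still open, as far as these compounds go, is what a [3-(trifluoromethyl)phenyl]amino group on that carbonyl carbon would give, which would separate the loss of the urea nitrogen from the change of ring substituents. From the compounds shown here alone, a carboxylic acid in place of the methyl ester is also open.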